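Amide substitution on a quinolinone lysophosphatidic acid receptor series

This account rests on a few compounds, and the source may have more. Where it says the series, first, only, none or still open, it means among the compounds named here.

Measured compounds:
- Compound 1, `CCN1CCc2ccc(-n3cc(C(=O)N4CCC(F)CC4)c4cc(OC)c(OC)cc4c3=O)cc21`: 120 nM
- Compound 2, `CCOc1ccc(-n2cc(C(=O)N3CCC(F)CC3)c3cc(OC)c(OC)cc3c2=O)cc1`: 750 nM

For the measured compounds named here, in an assay on CHO cells for antagonist activity at lysophosphatidic acid receptor 5 (Rattus norvegicus), read by cAMP accumulation, with a stated time of 30 min (on this read-out lower numbers stand for stronger inhibition and higher numbers for weaker inhibition), compound 2 gives 750 nM, the higher of the two numbers measured so far. Its nearest neighbour is compound 1, and the step of a 6.3-fold higher number from compound 1 to compound 2 (0.80 log units; beyond the scatter) arises from the exchange of the group on the aromatic nitrogen. Compound 3, `CCCCCCN(C)C(=O)c1cn(-c2ccc(OCC)cc2)c(=O)c2cc(OC)c(OC)cc12`, is not yet measured in this assay. It differs from compound 2 at another place: hexyl(methyl)amino in place of 4-fluoropiperidin-1-yl on a carbonyl carbon. Going by the values given here, no measured step touches the amide portion of the shared core; the only step on record, a 6.3-fold higher number from compound 1 to compound 2 (0.80 log units; beyond the scatter), concerns the aromatic nitrogen substituent and so gives no direct guide here. With no comparable change to lean on, the expected step of a 1.1-fold higher number from compound 2 to compound 3 (0.03 log units; within the scatter) is none beyond the scatter, but the uncertainty is wide. Compound 3 is therefore estimated at 800 nM, within a range of 200 nM to 3500 nM.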

Compound 3, half-maximal inhibitory concentration: > 10000 nM
Compound 3: no number, only a limit (the forecaster's own chance of this, stated with the estimate: 10%); at least 12-fold (1.09 log units) between middle value and limit.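

For the compounds shown here, the earlier pair showed only that the group on the aromatic nitrogen affects the read-out; this result shows that the group on the carbonyl carbon does too. In this assay the exchange of 4-fluoropiperidin-1-yl for hexyl(methyl)amino gives an at least 13-fold higher number from compound 2 to compound 3 (1.12 log units; beyond the scatter), so the open hexyl(methyl)amino group is not tolerated as a replacement here. Going by these compounds, the value for compound 3 is a limit of the assay and not a number, so the true size of the loss stays unknown: the limit of > 10000 nM in this assay, at which 1 of the 3 values shown sits.

The compounds shown do not separate the loss of the ring from the length of the hexyl chain, and a shorter open amine such as dimethylamino or an unfluorinated piperidin-1-yl would bear on that. On these data alone, whether the same change would cost as much with 1-ethyl-2,3-dihydro-1H-indol-6-yl on the aromatic nitrogen also remains open.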